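The source may hold more compounds than are shown below. What is called first, only, known or untested is meant among the compounds shown, and "the series" means these compounds.

Compound 1 `CCCCNC(=O)N1CC1C#N` carries a butyl chain on an amide-type nitrogen of the shared core. In a functional assay on MCF7 cells (Homo sapiens) for inhibition (a lower number here means a stronger inhibitor, a higher number a weaker inhibitor), compound 1 is reported only as a limit, > 12000 nM. Compound 2 `CC(=O)c1cccc(NC(=O)N2CC2C#N)c1` is the other measured member of the set, and in this assay compound 2 gives 3600 nM. Compound 3 `CNC(=O)N1CC1C#N` is not yet measured. It differs from compound 1 in one place: hydrogen in place of propyl on a saturated chain carbon bound to an amide-type nitrogen. Among the compounds with values here, no measured pair in this small set shows what such a shortening of the chain does. Compound 1 stands at a limit, as the limit of > 12000 nM in this assay, at which 1 of the 2 values shown sits, shows, and compound 3 keeps the same core with a shorter chain. The step from compound 1 to compound 3 is expected to be a step that the limit leaves unreadable from compound 1 to compound 3, with a good chance that only a limit is returned again. Compound 3 is therefore estimated at 15000 nM, in a range from 5000 nM to 50000 nM.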

Compound 3, half-maximal inhibitory concentration: 27000 nM
For compound 3 the middle estimate is 1.8-fold (0.26 log units) below the measured one; the range from low to high includes it.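

No step can be read from compound 1 to compound 3, because compound 1 is reported only as a limit: the limit of > 12000 nM in this assay, at which 1 of the 3 values shown sits.

The compounds shown leave open how shortening the chain on the amide-type nitrogen changes inhibition in this assay, since no two exact values differ in that one place.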